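A methyl group on the chain of compound 2

The source may report more compounds than this note shows. Statements on the series, on what has been measured and on what is new or still open speak of the compounds shown alone.

Measured so far in a physicochemical assay for metabolic stability, in phosphate buffer, at pH 7.4; a lower number here means that the compound disappears faster, a higher number that the compound lasts longer:
Compound 1 `Cc1nc(C)c(C(=O)NCC(=O)Oc2ccc(-c3cc(=O)c4c(O)c(O)c(O)cc4o3)cc2)nc1C`: > 72 h
Compound 2 `Cc1nc(C)c(COC(=O)NCC(=O)Oc2ccc(-c3cc(=O)c4c(O)c(O)c(O)cc4o3)cc2)nc1C`: 14.3 h

Compound 1 stands at > 72 h, which is a limit of the assay and not a number. Within the data shown here, compound 2, at 14.3 h, holds the only true number in this small set, so it has no numerical neighbour to be ranked against.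

Compound 3 `Cc1nc(C)c(COC(=O)N[C@H](C)C(=O)Oc2ccc(-c3cc(=O)c4c(O)c(O)c(O)cc4o3)cc2)nc1C` differs from compound 2 at one place, the saturated chain carbon bound to an amide-type nitrogen and a carbonyl carbon: methyl in place of hydrogen on a saturated chain carbon bound to an amide-type nitrogen and a carbonyl carbon.

Among the measured compounds shown here, the only measured step is an at least 5.0-fold lower number from compound 1 to compound 2 (0.70 log units; beyond the scatter). It lies at another place, where (3,5,6-trimethylpyrazin-2-yl)methoxy stands in place of 3,5,6-trimethylpyrazin-2-yl on a carbonyl carbon. For the measured compounds named here, it shows that this assay can separate compounds of this kind, but it gives only indirect guidance, since no step at the chain carbon has been measured. The step expected here is a 1.5-fold higher number from compound 2 to compound 3 (0.19 log units; within the scatter), small and leaning toward a longer half-life. Compound 3 is estimated at 22 h, with an expected range from 10 h to 50 h.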

Compound 3, half-life: 27.8 h
Estimate against measurement, compound 3: 1.3-fold (0.10 log units) below, and the stated range covers the measured number.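

Among these compounds, at the saturated chain carbon bound to an amide-type nitrogen and a carbonyl carbon, the first step that can be read in this assay is a 1.9-fold higher number from compound 2 to compound 3 (0.29 log units; within the scatter). Methyl in place of hydrogen at this place therefore gives no separation that exceeds the usual scatter, and the half-life of this carbamate series can be said to stay in one range with either group on the chain carbon. Unlike the earlier step, whose starting point for compound 1 is a limit of the assay and not a number, this step joins two true numbers, so its size can be read directly: the limit of > 72 h in this assay, at which 1 of the 3 values shown sits.

The compounds shown leave open whether an ethyl, isopropyl or benzyl group on this same carbon would give a step beyond the scatter in this assay, since a single methyl is the only group shown there besides hydrogen. They also leave open whether methyl at this place would give a similar step with 3,5,6-trimethylpyrazin-2-yl on the carbonyl carbon in place of (3,5,6-trimethylpyrazin-2-yl)methoxy.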